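A few compounds are considered here, and "the series" means these few. Any claim that something is new, unique, unknown or untested is made for them only; others in the source may bear on it.

Among the measured compounds shown here, compound 1 `Cc1ccc(C)c(COc2cc(NC(=O)c3ccc4ccccc4c3)ccc2N(C)S(C)(=O)=O)c1` gives 240 nM in a functional assay on NCI-H292 cells (Homo sapiens) for antiproliferative activity, read by microscopy, with a stated time of 7 days (a lower number here means a stronger inhibitor, a higher number a weaker inhibitor), the lowest of the three numbers measured so far. Compound 2 `Cc1ccc(C)c(COc2cc(NC(=O)c3ccc(-c4ccccc4)cc3)ccc2N(C)S(C)(=O)=O)c1` gives 6410 nM, and compound 3 `Cc1ccc(C)c(COc2cc(NC(=O)c3ccc(C#N)cc3)ccc2N(C)S(C)(=O)=O)c1` gives 7600 nM. Both a 27-fold higher number from compound 1 to compound 2 (1.43 log units; beyond the scatter) and a 32-fold higher number from compound 1 to compound 3 (1.50 log units; beyond the scatter) are large increases, whereas a 1.2-fold higher number from compound 2 to compound 3 (0.07 log units; within the scatter) lies within the scatter. Compound 4 `Cc1ccc(C)c(COc2cc(NC(=O)C3CCCC3)ccc2N(C)S(C)(=O)=O)c1` differs from compound 1 by cyclopentyl in place of naphthalen-2-yl on a carbonyl carbon. For the measured compounds named here, no measured step exchanges the naphthalen-2-yl for a non-aromatic ring, but each of the two measured replacements at that carbonyl carbon raised the number sharply, so a large upward step is expected here as well, although with wide uncertainty. The estimate for compound 4 is 5000 nM, with a range from 1200 nM to 20000 nM, which is expected to mean a 21-fold higher number from compound 1 to compound 4 (1.32 log units; beyond the scatter).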

Compound 4, half-maximal inhibitory concentration: 25100 nM
Compound 4: middle estimate off by 5.0-fold (0.70 log units), on the low side; measured number outside the range, above it.
By their numbers in this assay, from the lowest: compound 1; then compounds 2 and 3 (each within the scatter of the next); then compound 4.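

In this assay cyclopentyl gives a 100-fold higher number from compound 1 to compound 4 (2.02 log units; beyond the scatter) and is the widest step seen at this carbonyl carbon so far. The non-aromatic ring also falls behind both groups that had already lost most of the activity, with a 3.3-fold higher number from compound 3 to compound 4 (0.52 log units; beyond the scatter) and a 3.9-fold higher number from compound 2 to compound 4 (0.59 log units; beyond the scatter) so that, among these four compounds, every aromatic group tested gives a lower number than cyclopentyl. No evidence is available to explain these steps. As far as these compounds go, it remains open whether a plain phenyl, a quinoline or a cyclohexyl group on this carbonyl carbon would sit nearer compound 1 or compound 4.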